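This account rests on a few compounds, and the source may have more. Where it says the series, first, only, none or still open, it means among the compounds named here.

compound 1 `O=C(CCCCC1CCSS1)NO`: "not determined" (no result reported)
compound 2 `O=C(CCCCC1CCSS1)Nc1ccc(OC(F)(F)F)cc1`: 88.6%
compound 3 `O=C(CCCCC1CCSS1)Nc1cccc2ccccc12`: "not determined" (no result reported)

Among the compounds with values here, in a functional assay on PC-3 cells (Homo sapiens) for inhibition, read by MTT assay, with a stated time of 24 h, tested at 100 ug/mL (on this read-out higher numbers stand for more inhibition of growth at the one concentration tested and lower numbers for less inhibition of growth), compound 2 gives 88.6%, the only number. Compound 1 and compound 3 have no result, so compound 2 cannot be ranked against either of them. Compound 4 `O=C(CCCCC(S)CCS)Nc1ccc(OC(F)(F)F)cc1` is the next to be read, and its change from compound 2 is a group of 5 heavy atoms (3 carbon, 2 sulfur; no ring) in place of a group of 5 heavy atoms (3 carbon, 2 sulfur; one five-membered non-aromatic ring with 2 hetero atoms), on a saturated chain carbon, four bonds along the chain from a carbonyl carbon. Within the data shown here, no measured step covers this change, so the expectation rests on compound 2 alone, at 88.6%. A small fall in this assay is expected, not clearly beyond the scatter. The expected step is a number 8.6 percentage points lower from compound 2 to compound 4 (within the scatter). Compound 4 is estimated at 80%, with an expected range of 58% to 95%.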

Compound 4, percent growth inhibition at one concentration: 75.5%
Compound 4: the middle estimate sits 4.5 percentage points above what was measured, and the stated range covers the measured number.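

In this assay, replacing the five-membered ring with the open 1,3-disulfanylpropyl group at this chain position gives a number 13.1 percentage points lower from compound 2 to compound 4 (beyond the scatter). The ring is therefore not essential for growth inhibition in this pair, as compound 4 still gives 75.5%, but opening it has a cost. Nothing measured on these compounds speaks to the reason for this step.

From the compounds shown here alone, whether the same step holds with a different group on the amide nitrogen remains open. Also open, going by these compounds, is how a carboxylic acid in place of the 1,3-disulfanylpropyl group would read.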